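This account rests on a few compounds, and the source may have more. Where it says the series, first, only, none or still open, it means among the compounds named here.

Measured compounds:
compound 1 `C[C@]1(CN2CCc3nc(-c4ccc(F)cc4)oc3C2)Cn2cc([N+](=O)[O-])nc2O1`: > 32 ug/mL
compound 2 `C[C@]1(CN2CCn3cc(-c4ccc(F)cc4)nc3C2)Cn2cc([N+](=O)[O-])nc2O1`: "not determined" (no result reported)
compound 3 `C[C@]1(CN2CCc3nc(C4CCCCC4)ccc3C2)Cn2cc([N+](=O)[O-])nc2O1`: "not determined" (no result reported)

In an ADME assay on Vero cells (Chlorocebus sabaeus) for cytotoxicity, read by MTT assay, with a stated time of 72 h (on this read-out higher numbers stand for lower toxicity in this test and lower numbers for higher toxicity in this test), compound 1 gives only a limit, > 32 ug/mL, and that entry sits at the limit of > 32 ug/mL in this assay, at which 1 of the 3 values shown sits. For compound 2 the entry in this assay reads "not determined" (no result reported). Among the compounds with values here, for compound 3 it likewise reads "not determined" (no result reported), so compound 3 stands on no number at all, and no step to or from it can be sized. Compound 4 `C[C@]1(CN2CCc3nc(-c4cccc(F)c4F)ccc3C2)Cn2cc([N+](=O)[O-])nc2O1` is the compound to be measured next. Its change from compound 3: 2,3-difluorophenyl in place of cyclohexyl on an aromatic carbon. Within the data shown here, no step between measured compounds exists, so neither size nor direction can be taken from the data; the expectation rests on compound 1 alone. Compound 4 is expected to give about 40 ug/mL in this assay, estimated between 15 ug/mL and 120 ug/mL, most likely again as a limit.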

Compound 4, half-maximal cytotoxic concentration: > 32 ug/mL
Compound 4 was reported as a limit; the forecaster's own chance of this, stated with the estimate: 70%; the middle value is on the limit's open side.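

In this assay compound 4 gives > 32 ug/mL, which is a limit. Within the data shown here, the entry for compound 3 holds no number, so no step between compound 3 and compound 4 can be read. The compounds shown leave open how far any value lies beyond that limit: the limit of > 32 ug/mL in this assay, at which 2 of the 4 values shown sit.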